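The compounds below may be only part of what the source reports. "The series", "measured", "known", "first", "only" and "open" are said of these compounds alone.

The measured compounds, with their numbers in an assay on HEK293 cells for displacement of a labelled ligand from 5-hydroxytryptamine receptor 6 (Homo sapiens), with a stated time of 60 min, tested at 1 uM, in the presence of a further agent that is not named here; a lower number here means a weaker effect, a higher number a stronger effect of the compound at the concentration tested:
Compound 1 `COc1ccc(S(=O)(=O)NCCN2CCC(CCC(=O)c3cc(Cl)c(N)cc3OC)CC2)cc1Br` gives 72%.
Compound 2 `COc1ccc(S(=O)(=O)NCCN2CCC(CCC(=O)c3cc(Cl)c(N)cc3OC)CC2)cc1` gives 52%.
Compound 3 `COc1ccc(S(=O)(=O)CCCN2CCC(CCC(=O)c3cc(Cl)c(N)cc3OC)CC2)cc1` gives 33%.

On these three numbers compound 2 stands second highest: compound 3 lies below it, beyond the scatter, and compound 1 lies above it, also beyond the scatter. Compound 4 `COc1cc(N)c(Cl)cc1C(=O)CCC1CCN(CCNS(=O)(=O)c2ccc(N)c(Br)c2)CC1` has not been measured in this assay. It differs from compound 2 in one place: 4-amino-3-bromophenyl in place of 4-methoxyphenyl on a sulfonyl sulfur. Among the measured compounds shown here, only one measured step bears on this change, and only in part: a number 20 percentage points lower from compound 1 to compound 2 (beyond the scatter), the step of hydrogen in place of bromo on an aromatic carbon. For the measured compounds named here, compound 4 brings a bromo back, so the reverse of that step is the guide, but the entering group also carries an amino in place of the methoxy, and no measured pair tests that part of the change. Compound 4 is therefore expected to move upward from compound 2 by about a number 16 percentage points higher from compound 2 to compound 4 (beyond the scatter). The uncertainty is wide. The estimate for compound 4 is 68%, with a range from 50% to 86%.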

Compound 4, a percentage reported as inhibition, at one concentration (the size of the read-out at that concentration, not a potency): 85%
Estimate against measurement, compound 4: 17 percentage points below, within the range that was stated.
By their numbers in this assay, from the lowest: compound 3; then compound 2; then compound 1; then compound 4.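

In this assay, the full change on the sulfonyl sulfur, from 4-methoxyphenyl to 4-amino-3-bromophenyl, gives a large rise: a number 33 percentage points higher from compound 2 to compound 4 (beyond the scatter). Among the compounds shown here, the amino part, which no earlier pair could test, can now be read on its own, since with the bromo kept in place, amino in place of methoxy gives a number 13 percentage points higher from compound 1 to compound 4 (beyond the scatter). The amino therefore adds to the rise that the bromo already gives at this position, rather than merely leaving it intact. Nothing available here explains why either group raises the number.

The compounds shown leave open whether the amino gives a rise without the bromo, and whether a chloro in place of the bromo would hold the number. They also leave open how a hydroxyl or a methylamino in place of the amino would read.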